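The compounds below may be only part of what the source reports. "The series", "measured", "known", "first", "only" and "open" are said of these compounds alone.

In a functional assay on M14 cells (Homo sapiens) for cytotoxicity (a lower number here means a stronger inhibitor of growth, a higher number a weaker inhibitor of growth), compound 1 `COc1ccc(C2=C(c3ccc(SC)cc3)CC3CCCN3C2=O)cc1C` gives 200 nM. Compound 2 `CSc1ccc(C2=C(c3ccc(C)c(C)c3)C(=O)N3CCCC3C2)cc1` gives 800 nM, a modest change described as a 4.0-fold higher number from compound 1 to compound 2 (0.60 log units; beyond the scatter). Compound 3 `CSc1ccc(C2=C(c3ccc(O)cc3)C(=O)N3CCCC3C2)cc1` yields no number, only a limit of the assay, > 100000 nM. Both steps leading to it are large and beyond the scatter, so it sits at the weak end of the three measured compounds.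

Compound 4 `CSc1ccc(C2=C(c3ccc(Br)cc3)C(=O)N3CCCC3C2)cc1` keeps the core of compound 3 and changes one group: bromo in place of hydroxy on an aromatic carbon. In words, this is bromo in place of hydroxy on an aromatic carbon, or 4-hydroxyphenyl to 4-bromophenyl. Within the data shown here, the steps that bear on this change are an at least 500-fold higher number from compound 1 to compound 3 (2.69 log units; beyond the scatter) and an at least 120-fold higher number from compound 2 to compound 3 (2.09 log units; beyond the scatter). Each of them ends in the 4-hydroxyphenyl group and starts from an aryl group without hydroxy. Read in reverse, they suggest that removing the hydroxy could restore much of the growth inhibition, although neither compound 1 nor compound 2 carries bromo, so the size remains uncertain. A large move towards a lower number is therefore expected, with the estimated change being an at least 100-fold lower number from compound 3 to compound 4 (2.00 log units; beyond the scatter). The estimate for compound 4 is 1000 nM, with an expected range from 200 nM to 6000 nM.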

Compound 4, concentration for 50% growth inhibition: 9000 nM
The estimate for compound 4 lay 9.0-fold (0.95 log units) below the measured number; measured number above the stated range.
By their numbers in this assay, from the lowest: compound 1; then compound 2; then compound 4. At a limit, above all of these: compound 3.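

In this assay, bromo in place of hydroxy on the aromatic carbon, para to a large group, brings growth inhibition back to a measurable level, with an at least 11-fold lower number from compound 3 to compound 4 (1.04 log units; beyond the scatter). Losing the hydroxy does not by itself reach the level of the aryl groups in the earlier compounds: the 4-bromophenyl group still gives an 11-fold higher number from compound 2 to compound 4 (1.05 log units; beyond the scatter) and a 45-fold higher number from compound 1 to compound 4 (1.65 log units; beyond the scatter), so a hydroxy-free aryl group at this place is not enough to match the 3,4-dimethylphenyl or 4-methoxy-3-methylphenyl group. The true size of the gain over compound 3 stays unknown, as that compound stands at a limit of the assay: the limit of > 100000 nM in this assay, at which 1 of the 4 values shown sits.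

The compounds shown leave open whether the remaining gap to compound 1 and compound 2 comes from bromo itself or from the absence of a second group on the ring, and no pair here separates the two. They also leave open how a single chloro, methyl, methoxy or amine at this place would compare with bromo in this assay.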